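Primary Carboxamide in Place of a tert-Butyl Amide

The source may hold more compounds than are shown below. What is called first, only, known or untested is meant among the compounds shown, and "the series" means these compounds.

Compound 3 `C[C@H](NC(=O)[C@]1(Cc2ccccc2)CCN1C(=O)OCc1ccccc1)C(=O)NC(C)(C)C` stands at the top of the measured range in an ADME assay on HELF cells (Homo sapiens) for cytotoxicity, with a stated time of 3 days; a lower number here means that less compound is tolerated, a higher number that more compound is tolerated. Compound 3 gives only a limit there, > 100000 nM. Compound 1 `C[C@H](NC(=O)[C@]1(Cc2ccccc2)CCN1C(=O)OCc1ccccc1)C(=O)N(C)C` also reaches only a limit in this assay, namely > 100000 nM. Among the measured compounds shown here, compound 2 `CC(C)C[C@H](NC(=O)[C@]1(Cc2ccccc2)CCN1C(=O)OCc1ccccc1)C(N)=O` is the one compound with a number: in this assay compound 2 gives 100000 nM. The three steps among these compounds are all of unreadable size: a number no higher from compound 1 to compound 2 (the limit leaves the size open), a step that the two limits leave unreadable from compound 1 to compound 3 and a number no lower from compound 2 to compound 3 (the limit leaves the size open). The reason is the limit of > 100000 nM in this assay, at which 2 of the 3 values shown sit, so none of the measured steps shows how far apart the compounds really lie.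

Compound 4 `CC(C)[C@H](NC(=O)[C@]1(Cc2ccccc2)CCN1C(=O)OCc1ccccc1)C(N)=O` differs from compound 3 in one place: 1-carbamoyl-2-methylpropyl in place of 1-((tert-butyl)carbamoyl)ethyl on an amide-type nitrogen. For the measured compounds named here, the step from compound 2 to compound 3 is the only one that also exchanges a primary carboxamide for a substituted amide, and its size is not readable. Compound 4 carries a primary carboxamide like compound 2, whose value of 100000 nM sits at the top of the range. The step of a number no higher from compound 3 to compound 4 (the limit leaves the size open) is therefore expected to stay within the scatter. For compound 4 the expected value in this assay is 100000 nM, in a range from 50000 nM to 200000 nM.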

Compound 4, minimum cytotoxic concentration: > 100000 nM
Compound 4 gave a limit, no number; the forecaster's own chance of this, stated with the estimate: 50%; the middle value sits exactly at the limit.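

Compound 4 adds another limit in this assay: > 100000 nM is a limit and not a number. Among the compounds shown here, a primary carboxamide therefore does not always go with a readable number here: with 1-carbamoyl-2-methylpropyl on the amide-type nitrogen, the result is of the same kind as for the substituted amides in the earlier compounds, and the exchange of isobutyl for isopropyl gives a number no lower from compound 2 to compound 4 (the limit leaves the size open). None of the steps to compound 4 can be read for size, because the values sit at the limit: the limit of > 100000 nM in this assay, at which 3 of the 4 values shown sit.

As far as these compounds go, how far compound 1, compound 3 and compound 4 lie past the limit stays open, and so does whether the exchange of isobutyl for isopropyl has any real size. Also open, from the compounds shown here alone, is whether a carboxylic acid or an amine in place of the primary carboxamide, or a longer chain in place of isopropyl, would give a readable number in this assay.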